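Replacing bromo with carboxymethyl: expected cytotoxicity of compound 3

The source may report more compounds than this note shows. Statements on the series, on what has been measured and on what is new or still open speak of the compounds shown alone.

Compound 2, with the structure `CCOC(=O)CCCCCOc1cccc(CN(C(=O)c2ccc(-c3cccc(Br)c3)cc2)C(C)C)c1`, was tested in an ADME assay on Raji cells (Homo sapiens) for cytotoxicity, read by CellTiter-Glo and resazurin assay, with a stated time of 72 h; on this read-out lower numbers stand for an effect already at smaller amounts and higher numbers for an effect only at larger amounts of compound. In this assay compound 2 gives > 26000 nM, which is a limit of the assay and not a number. Its nearest measured neighbour is compound 1, `CCOC(=O)CCCCCOc1cccc(CN(C(=O)c2ccc(-c3ccc4c(c3)OCCO4)cc2)C(C)C)c1`, which carries a 2,3-dihydro-1,4-benzodioxin-6-yl group where compound 2 carries 3-bromophenyl. In this assay compound 1 gives > 24400 nM, again a limit rather than a number. The step that the two limits leave unreadable from compound 1 to compound 2 therefore cannot be read, because both ends rest on limits, the limit of > 24400 nM in this assay, at which 1 of the 2 values shown sits, and (the limit of > 26000 nM in this assay, at which 1 of the 2 values shown sits).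

Compound 3, `CCOC(=O)CCCCCOc1cccc(CN(C(=O)c2ccc(-c3cccc(CC(=O)O)c3)cc2)C(C)C)c1`, is not yet measured. It differs from compound 2 by carboxymethyl in place of bromo on an aromatic carbon. Among the measured compounds shown here, no measured step concerns this change; the only measured step, between two limits, gives no size and no direction. The account therefore expects the step that the limit leaves unreadable from compound 2 to compound 3 to stay within the scatter, with the result most likely again reported as a limit. For compound 3 in this assay the estimate is 30000 nM, with a range from 12000 nM to 90000 nM.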

Compound 3, half-maximal effective concentration: > 26000 nM
Compound 3: only a limit was reported (the forecaster's own chance of this, stated with the estimate: 85%); the middle value lies beyond the limit too.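

In this assay compound 3 gives > 26000 nM, a limit of the assay and not a number. The steps to compound 3 from compound 1 and from compound 2 therefore cannot be read. The compounds shown leave open at what amount compound 1, compound 2 or compound 3 would reach a half-maximal effect on Raji cells, and whether exchanging these groups changes it.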